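This account rests on a few compounds, and the source may have more. Where it says the series, first, only, none or still open, it means among the compounds named here.

Compound 1 `C[C@@H](O)[C@H]1C(=O)N2C(C(=O)OCOC(=O)C(C)(C)C)=C(S[C@@H]3CN[C@H](C(=O)Nc4cccc(C(=O)OCOC(=O)C(C)(C)C)c4)C3)[C@H](C)[C@H]12`: in an ADME assay for metabolic stability, read by LC-MS, with a stated time of 3 h, at pH 6.5, tested at 50 uM (a lower number here means that less of the compound is left, a higher number that more of the compound is left), compound 1 gives > 95%, which is a limit of the assay.
Compound 2 `C[C@@H](O)[C@H]1C(=O)N2C(C(=O)OCOC(=O)C(C)(C)C)=C(S[C@@H]3CN[C@H](C(=O)Nc4cccc(C(=O)O)c4)C3)[C@H](C)[C@H]12`: in this assay compound 2 gives > 95%, again a limit of the assay.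
Compound 3 `C[C@@H](O)[C@H]1C(=O)N2C3=C(S[C@@H]4CN[C@@H](C4)C(=O)Nc4cccc(c4)C(=O)OCc4oc(=O)oc4COC3=O)[C@H](C)[C@H]12`: in this assay compound 3 gives > 95%, also a limit of the assay.

Compound 2 therefore stands at the limit, together with every other measured compound, as all three values sit at the limit of > 95% in this assay, at which 3 of the 3 values shown sit. For the measured compounds named here, the single step between measured compounds that differ in one place, a step that the two limits leave unreadable from compound 1 to compound 2, cannot be sized because both of its ends rest at the limit of > 95% in this assay, at which 3 of the 3 values shown sit.

Compound 4 `CCOC(=O)OCOC(=O)C1=C(S[C@@H]2CN[C@H](C(=O)Nc3cccc(C(=O)O)c3)C2)[C@H](C)[C@@H]2[C@@H]([C@@H](C)O)C(=O)N12` differs from compound 2 by ethoxy in place of tert-butyl on a carbonyl carbon. Going by the values given here, no measured step bears directly on this exchange, and the one measured step, a step that the two limits leave unreadable from compound 1 to compound 2, is unreadable, so no direction or size of effect can be drawn from the measured data. Since every measured compound sits at the limit of > 95% in this assay, at which 3 of the 3 values shown sit, compound 4 is expected to give 95%, with a range from 85% to 100%. The expected step of a number no higher from compound 2 to compound 4 (the limit leaves the size open) is accordingly estimated to be none beyond the scatter, with the result most likely reported again as a limit.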

Compound 4, percent of the compound remaining: > 95%
Compound 4 gave a limit, no number; the forecaster's own chance of this, stated with the estimate: 80%; the middle value sits exactly at the limit.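

The exchange from compound 2 to compound 4 yields no readable step, because both compounds rest at a limit: the limit of > 95% in this assay, at which 4 of the 4 values shown sit.

The compounds shown leave open how much of each actually remains in this assay, and so whether ethoxy in place of tert-butyl makes any difference there.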